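The source may hold more compounds than are shown below. What is called first, only, known or untested is meant among the compounds shown, and "the series" means these compounds.

Measured in a functional assay on MCF7 cells (Homo sapiens) for antiproliferative activity, read by MTT assay; on this read-out higher numbers stand for weaker inhibition and lower numbers for stronger inhibition:
- compound 1 `CCCCCCCCCCCCCCCc1cc(=O)c2c(O)c(C)c(OCOC)cc2o1`: > 67200 nM
- compound 2 `CC/C=C\C/C=C\C/C=C\CCCCCCCc1cc(=O)c2c(O)c(C)c(OCOC)c(C)c2o1`: > 84100 nM
- compound 3 `CCCCCCCCCCCCCCCc1cc(=O)c2c(O)c(C)c(O)c(C)c2o1`: > 67200 nM

All three entries are limits of the assay, not numbers. Compound 3 stands at > 67200 nM, which is a limit. Compound 4 `CCCCCCCCCCCCCCCc1cc(=O)c2c(O)c(C)c(OCOC)c(C)c2o1` differs from compound 3 by methoxymethyl in place of hydrogen on an oxygen on an aromatic ring. Compound 1 also carries methoxymethoxy, and its > 67200 nM is a limit. Compound 2 carries it too, and its > 84100 nM is likewise a limit. The step expected in this assay is an at least 1.0-fold lower number from compound 3 to compound 4 (0.01 log units; that floor lies within the scatter), none beyond the scatter and in no particular direction. The estimate for compound 4 is 65000 nM, with a range of 30000 nM to 100000 nM, and a limit rather than a number is the likely report.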

Compound 4, half-maximal inhibitory concentration: > 67200 nM
Compound 4: no number, only a limit (the forecaster's own chance of this, stated with the estimate: 85%); middle value at least 1.0-fold (0.01 log units) away from the limit.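

Among these compounds, compound 4 gives only a limit, as do compound 1, compound 2 and compound 3, so no step to compound 4 can be read: the limit of > 67200 nM in this assay, at which 3 of the 4 values shown sit. The compounds shown leave open whether hydroxy versus methoxymethoxy, the chain or the methyl changes activity at all.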